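Swapping 4-bromophenyl for furan-2-yl

This account rests on a few compounds, and the source may have more. Where it says the series, first, only, none or still open, it means among the compounds named here.

Measured so far in a functional assay on HL-60 cells (Homo sapiens) for inhibition, read by MTT assay, with a stated time of 48 h, tested at 10 uM; on this read-out higher numbers stand for more inhibition of growth at the one concentration tested and lower numbers for less inhibition of growth:
- compound 1 `Cc1cc(=O)c2c(O)cc(OCc3ccc(Br)cc3)c([C@H]3CCN(C)C[C@H]3O)c2o1` gives 27%
- compound 2 `Cc1cc(=O)c2c(O)cc(OCc3ccc([N+](=O)[O-])cc3)c([C@H]3CCN(C)C[C@H]3O)c2o1` gives 14%
- compound 3 `Cc1cc(=O)c2c(O)cc(OC/C=C/c3ccccc3)c([C@H]3CCN(C)C[C@H]3O)c2o1` gives 21%

Compound 1 lies within the scatter of compound 3 and beyond the scatter above compound 2. Compound 4 `Cc1cc(=O)c2c(O)cc(OCc3ccco3)c([C@H]3CCN(C)C[C@H]3O)c2o1` is still unmeasured. It carries furan-2-yl in place of 4-bromophenyl on a saturated chain carbon bound to an oxygen on an aromatic ring. Within the data shown here, no measured compound carries furan-2-yl, so two steps serve only as rough guides. Replacing the whole 4-bromophenyl with 2-phenylethenyl gave a number 6 percentage points lower from compound 1 to compound 3 (within the scatter) in this series. Nitro in place of bromo on the same group gave a number 13 percentage points lower from compound 1 to compound 2 (beyond the scatter) as the other guide. Neither step offers a reason to expect a rise, so a small drop is expected, estimated as a number 8 percentage points lower from compound 1 to compound 4 (within the scatter) in this assay on this evidence. The estimate for compound 4 is 19% with an expected range from 8% to 31% around it.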

Compound 4, percent growth inhibition at one concentration: 32%
Beside the measured number, compound 4's estimate is 13 percentage points below it, outside the stated range (above it).
By their numbers in this assay, from the lowest: compounds 2, 3, 1 and 4 (each within the scatter of the next, the first and the last beyond it).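

In this assay, replacing 4-bromophenyl with the smaller furan-2-yl gives a number 5 percentage points higher from compound 1 to compound 4 (within the scatter) and so no detectable loss of growth inhibition. This shows that, at this place on a saturated chain carbon bound to an oxygen on an aromatic ring, a five-membered ring with a hetero atom can stand in for a six-membered ring of carbon only. Compound 4 also separates from two other compounds, with a number 11 percentage points higher from compound 3 to compound 4 (beyond the scatter) and a number 18 percentage points higher from compound 2 to compound 4 (beyond the scatter) in the same read-out, but nothing available explains these differences.

On these data alone, whether the ring oxygen of furan-2-yl matters remains open, and thiophen-2-yl or plain phenyl at the same place would test that. As far as these compounds go, how an amine on the ring, as in 4-aminophenyl, would compare also remains open.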